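Chloro in place of fluoro: working notes on compound 3

The source may hold more compounds than are shown below. What is called first, only, known or untested is meant among the compounds shown, and "the series" means these compounds.

Measured in a functional assay on GC3/C1 cells (Homo sapiens) for cytotoxicity, read by MTT assay, with a stated time of 6 days; on this read-out lower numbers stand for stronger inhibition and higher numbers for weaker inhibition:
- compound 1 `COc1ccccc1NC(=O)SC[C@H](NC(C)=O)C(=O)O`: > 200000 nM (a limit)
- compound 2 `CC(=O)N[C@@H](CSC(=O)Nc1ccccc1F)C(=O)O`: > 200000 nM (a limit)

In this assay compound 2 has no number, only a limit of > 200000 nM. Within the data shown here, compound 1 gives no number either, and the whole series so far comes down to the limit of > 200000 nM in this assay, at which 2 of the 2 values shown sit.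

Compound 3 `CC(=O)N[C@@H](CSC(=O)Nc1ccccc1Cl)C(=O)O` carries one change, chloro in place of fluoro on an aromatic carbon, ortho to a large group.

Among the measured compounds shown here, the only measured step that bears on this change is a step that the two limits leave unreadable from compound 1 to compound 2, a swap of methoxy for fluoro. That step gives no size and no direction to carry over. No step beyond the scatter is therefore expected in this assay, and no direction is favoured. The step expected is a number no higher from compound 2 to compound 3 (the limit leaves the size open). This expectation rests on compound 2, which stays at > 200000 nM, a limit, and a further limit is the likeliest report for the new compound. Compound 3 is estimated at 200000 nM, with an expected range from 100000 nM to 400000 nM.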

Compound 3, half-maximal inhibitory concentration: > 200000 nM
Compound 3: no number, only a limit (the forecaster's own chance of this, stated with the estimate: 85%); the middle value sits exactly at the limit.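

Compound 3 gives > 200000 nM, which is a limit and not a number. No step can be read between compound 3 and either compound 1 or compound 2, and the series shows one shared result: the limit of > 200000 nM in this assay, at which 3 of the 3 values shown sit.

The compounds shown leave open whether methoxy, fluoro and chloro differ at all in their effect on the read-out.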